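Moving a 3-Methoxyphenyl onto the Triazole of Compound 1

The source may report more compounds than this note shows. Statements on the series, on what has been measured and on what is new or still open speak of the compounds shown alone.

Measured compounds in a functional assay on HepG2 cells (Homo sapiens) for inhibition, read by MTT assay, with a stated time of 24 h; a higher number here means a weaker inhibitor, a lower number a stronger inhibitor:
- compound 1 `CC1(C)[C@H]2CC[C@]1(C)N(Cc1cn(-c3ccc(F)cc3)nn1)C(=O)C2`: 90 nM
- compound 2 `CC1(C)[C@H]2CC[C@]1(C)N(Cc1cn(-c3cccc(Br)c3)nn1)C(=O)C2`: 20 nM
- compound 3 `CC1(C)[C@H]2CC[C@]1(C)N(Cc1cn(-c3ccc(Cl)cc3)nn1)C(=O)C2`: 90 nM

Compound 1 stands level with compound 3, and the two together hold the highest numbers of the three; its nearest neighbour in this assay is compound 3, with no change at the digits printed, and its furthest is compound 2, which gives a 4.5-fold lower number from compound 1 to compound 2 (0.65 log units; beyond the scatter).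

The new compound 4 `COc1cccc(-n2cc(CN3C(=O)C[C@@H]4CC[C@@]3(C)C4(C)C)nn2)c1` differs from compound 1 as follows: 3-methoxyphenyl in place of 4-fluorophenyl on an aromatic nitrogen.

For the measured compounds named here, two measured steps bear on this change. Swapping one group on the aromatic carbon for another, as in no change at the digits printed from compound 1 to compound 3 (within the scatter), left the number unchanged. Placing a group at the 3-position of the phenyl ring instead of the 4-position, as in a 4.5-fold lower number from compound 1 to compound 2 (0.65 log units; beyond the scatter), lowered it beyond the scatter. Going by the values given here, compound 4 also carries its group at the 3-position, but it brings a methoxy group and one hydrogen-bond acceptor rather than a bromine, for which no measured step exists. A modestly lower number than that of compound 1 is therefore expected, though with wide uncertainty: the expected step is a 1.8-fold lower number from compound 1 to compound 4 (0.26 log units; within the scatter), and compound 4 is estimated at 50 nM, between 20 nM and 150 nM.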

Compound 4, half-maximal inhibitory concentration: 70 nM
Beside the measured number, compound 4's estimate is 1.4-fold (0.15 log units) below it, within the range that was stated.
By their numbers in this assay, from the lowest: compound 2; then compounds 4, 1 and 3 (each within the scatter of the next).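

In this assay, a group at the 3-position of the phenyl ring proves not to be enough on its own to reach the number of compound 2, since the methoxy in place of bromo gives a 3.5-fold higher number from compound 2 to compound 4 (0.54 log units; beyond the scatter). Against the 4-fluorophenyl and 4-chlorophenyl groups, the 3-methoxyphenyl stays inside the scatter, with a 1.3-fold lower number from compound 1 to compound 4 (0.11 log units; within the scatter) and a 1.3-fold lower number from compound 3 to compound 4 (0.11 log units; within the scatter). Among these four compounds, then, the lower number goes with the 3-bromophenyl group of compound 2 rather than with the 3-position as such, and compound 4 is the one that goes against a reading by position alone, while its hydrogen-bond acceptor brings no step beyond the scatter from compounds 1 and 3.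

The compounds shown leave open whether a 4-bromophenyl group would keep the low number of compound 2, which would separate the bromine itself from its position on the ring. They also leave open whether a 3-chlorophenyl, a 3-aminophenyl or a 3-carboxyphenyl group on the same aromatic nitrogen would fall with the bromo or with the methoxy compound. Nothing given here accounts for the gap between the bromo and methoxy groups.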